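Compound 2 Gains a 2-Methyl-1,3-Thiazol-4-yl Group

A few compounds are considered here, and "the series" means these few. Any claim that something is new, unique, unknown or untested is made for them only; others in the source may bear on it.

In a functional assay on MCF7 cells (Homo sapiens) for cytotoxicity (a higher number here means a weaker inhibitor, a lower number a stronger inhibitor), compound 1 `Cc1cc(Nc2nn(-c3ccc(F)cc3)c(=O)c3ccccc23)n[nH]1` gives 1600 nM and compound 2 `Cc1cc(Nc2nn(CC(C)C)c(=O)c3ccccc23)n[nH]1` gives 4200 nM as the higher number of the two, which makes compound 2 the weaker inhibitor of this pair. For the measured compounds named here, the single measured step (a 2.6-fold higher number from compound 1 to compound 2 (0.42 log units; beyond the scatter)) is modest and comes from isobutyl in place of 4-fluorophenyl on an aromatic nitrogen.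

Compound 3 `Cc1cc(Nc2nn(Cc3csc(C)n3)c(=O)c3ccccc23)n[nH]1` changes that same side chain (2-methyl-1,3-thiazol-4-yl in place of isopropyl on a saturated chain carbon bound to an aromatic nitrogen) so that isobutyl becomes (2-methyl-1,3-thiazol-4-yl)methyl. Compound 1 carries an aromatic ring on that nitrogen, and compound 3 brings a ring back, though one set on a saturated chain carbon. Going by the values given here, the step between compound 1 and compound 2 (a 2.6-fold higher number from compound 1 to compound 2 (0.42 log units; beyond the scatter)) is therefore the only guide, and a thin one, since no measured compound yet carries this kind of ring. The step expected in this assay is small and points toward a lower number (a 1.8-fold lower number from compound 2 to compound 3 (0.24 log units; within the scatter)) rather than a large gain. Compound 3 is estimated to give about 2400 nM in this assay with an expected range from 900 nM to 6000 nM for repeated measurements.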

Compound 3, half-maximal inhibitory concentration: > 30000 nM
Compound 3 was reported as a limit; the forecaster's own chance of this, stated with the estimate: 3%; middle value at least 12-fold (1.09 log units) from the limit.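

In this assay compound 3 is reported only as a limit of the assay and not as a number: the limit of > 30000 nM in this assay, at which 1 of the 3 values shown sits. Replacing isopropyl with 2-methyl-1,3-thiazol-4-yl on a saturated chain carbon bound to an aromatic nitrogen gives an at least 7.1-fold higher number from compound 2 to compound 3 (0.85 log units; beyond the scatter), so this side chain can shift the number by more than the modest step seen earlier. Exchanging the whole group on the aromatic nitrogen gives an at least 18-fold higher number from compound 1 to compound 3 (1.27 log units; beyond the scatter), and since both groups in this comparison carry a ring, the mere presence of a ring on this nitrogen does not keep the number low.

The compounds shown do not separate the parts of the new group, so the result could belong to the ring itself, its sulfur and nitrogen, its methyl or the saturated carbon that carries it. A plain benzyl group, or a thiazol-4-ylmethyl group without the methyl, would help to separate these possibilities, and the limit leaves the full size of both steps unknown.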